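Extending the Ester Chain: From Compound 2 to Compound 3

A few compounds are considered here, and "the series" means these few. Any claim that something is new, unique, unknown or untested is made for them only; others in the source may bear on it.

Among the measured compounds shown here, compound 2 `CCCCCCCCCOC(=O)CCC(=O)N1CCN(CCCOc2cc3c(Nc4ccc(F)c(Cl)c4)ncnc3cc2OC)CC1` stands lowest of the two numbers measured so far: in a functional assay on A549 cells (Homo sapiens) for cytotoxicity, read by MTT assay, with a stated time of 24 h, tested at 40 uM (a lower number here means a stronger effect, a higher number a weaker effect of the compound at the concentration tested), compound 2 gives 17.9%, whereas compound 1 `CCOC(=O)CCC(=O)N1CCN(CCCOc2cc3c(Nc4ccc(F)c(Cl)c4)ncnc3cc2OC)CC1` gives 67.4%. Compound 3 `CCCCCCCCCCCCCCCCCOC(=O)CCC(=O)N1CCN(CCCOc2cc3c(Nc4ccc(F)c(Cl)c4)ncnc3cc2OC)CC1` differs from compound 2 by octyl in place of hydrogen on a saturated chain carbon, nine bonds along the chain from an oxygen next to a carbonyl group. For the measured compounds named here, one measured step bears on this change: a number 49.5 percentage points lower from compound 1 to compound 2 (beyond the scatter). A chain extension of the same kind, carried further out, is therefore expected to lower the number again, but a smaller step is expected since compound 2 already sits far down, a number 7.9 percentage points lower from compound 2 to compound 3 (within the scatter). Compound 3 is estimated at 10%, within a range from 2% to 30%.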

Compound 3, a percentage reported as activity, at one concentration (the size of the read-out at that concentration, not a potency): 85.2%
The estimate for compound 3 lay 75.2 percentage points below the measured number; the whole stated range lies below it.
By their numbers in this assay, from the lowest: compound 2; then compound 1; then compound 3.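

In this assay, octyl in place of hydrogen, nine bonds along the chain from an oxygen next to a carbonyl group, gives a number 67.3 percentage points higher from compound 2 to compound 3 (beyond the scatter) and so turns the trend around. The earlier extension gave a number 49.5 percentage points lower from compound 1 to compound 2 (beyond the scatter), so across these compounds a longer chain at this position does not act in one direction. Nothing measured here explains this reversal.

The compounds shown leave open at which intermediate chain length the number turns upward. They also leave open whether a chain ending in an amine or a carboxylic acid would follow compound 2 or compound 3.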